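This account rests on a few compounds, and the source may have more. Where it says the series, first, only, none or still open, it means among the compounds named here.

Series notes. Among the compounds with values here, compound 1 `COc1ccc(C(=O)/C=C/c2cc(-c3cc(OC)c(OC)c(OC)c3)n[nH]2)cc1OC` and compound 2 `COc1cc(-c2cc(/C=C/C(=O)c3ccc(F)c(F)c3)[nH]n2)cc(OC)c1OC` are the two measured members. In a functional assay on Malme-3M cells (Homo sapiens) for inhibition, read by sulforhodamine B assay, with a stated time of 48 h (on this read-out lower numbers stand for stronger inhibition of growth and higher numbers for weaker inhibition of growth), compound 1 gives 1990 nM, the lowest of the two numbers, and in this assay compound 2 gives 2960 nM. Within the data shown here, the only measured step, a 1.5-fold higher number from compound 1 to compound 2 (0.17 log units; within the scatter), comes from exchanging the group on the carbonyl carbon: 3,4-difluorophenyl in place of 3,4-dimethoxyphenyl, and it stays within the scatter.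

Compound 3 `COc1cc(C(=O)/C=C/c2cc(-c3cc(OC)c(OC)c(OC)c3)n[nH]2)cc(OC)c1OC` differs from compound 1 by methoxy in place of hydrogen on an aromatic carbon, so the change sits on the same ring that was varied in the step from compound 1 to compound 2. That step bears on the present change and was within the scatter, so no step beyond the scatter is expected here in either direction, and the expected step is a 1.1-fold lower number from compound 1 to compound 3 (0.04 log units; within the scatter). Compound 3 is accordingly estimated at 1800 nM in this assay, with a range from 700 nM to 4500 nM.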

Compound 3, concentration for 50% growth inhibition: 1860 nM
Compound 3: middle estimate off by 1.0-fold (0.01 log units), on the low side; the measured number falls inside the stated range.
By their numbers in this assay, from the lowest: compounds 3, 1 and 2 (each within the scatter of the next).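

With methoxy in place of hydrogen on an aromatic carbon, ortho to a methoxy group and meta to a large group, the change is a 1.1-fold lower number from compound 1 to compound 3 (0.03 log units; within the scatter) in this assay and does not leave the scatter. This position therefore accepts an added group of 2 heavy atoms with no measurable change in growth inhibition, whereas the earlier step concerned only an exchange of the substituents on this ring. So far, neither an exchange nor an addition on this ring has produced a step beyond the scatter, and nothing available gives a reason for this result.

Going by these compounds, whether an amine, a carboxylic acid or a longer chain such as butoxy at this position would move the number beyond the scatter remains open. The compounds shown also leave open whether changes elsewhere on the shared core would have a larger effect.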